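Adding a Pyrrolidinyl Group to Compound 3

The source may hold more compounds than are shown below. What is called first, only, known or untested is meant among the compounds shown, and "the series" means these compounds.

Compound 1, `Cc1ccccc1Nc1ncnn1-c1cccc(Cl)c1Cl`, gives 17.8 nM in a functional assay for antagonist activity at P2X purinoceptor 7 (Homo sapiens), read by FLIPR and calcium flux; a higher number here means a weaker inhibitor, a lower number a stronger inhibitor.
Compound 2, `CCOc1ccccc1CNc1ncnn1-c1cccc(Cl)c1Cl`, gives 45.7 nM.
Compound 3, `Clc1cccc(-n2cnnc2NCc2cccnc2)c1Cl`, gives 355 nM.

Compound 3 has the highest number of the three and is therefore the weakest inhibitor in this set; compound 2 lies nearest to it and compound 1 furthest, both gaps beyond the usual scatter. Compound 4, `Clc1cccc(-n2cnnc2NCc2cccnc2N2CCCC2)c1Cl`, differs from compound 3 in one place: pyrrolidin-1-yl in place of hydrogen on an aromatic carbon. For the measured compounds named here, no measured pair shows a change of this kind, so its effect can only be estimated. The step of a 2.4-fold lower number from compound 3 to compound 4 (0.37 log units; beyond the scatter) is expected to be small, toward a lower number, and may not reach beyond the scatter. Compound 4 is therefore estimated at about 150 nM, within a range from 40 nM to 600 nM.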

Compound 4, half-maximal inhibitory concentration: 14.8 nM
Beside the measured number, compound 4's estimate is 10-fold (1.01 log units) above it; the whole stated range lies above it.
By their numbers in this assay, from the lowest: compounds 4 and 1 (each within the scatter of the next); then compound 2; then compound 3.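

In this assay, putting pyrrolidin-1-yl on the aromatic carbon next to the ring nitrogen gives a 24-fold lower number from compound 3 to compound 4 (1.38 log units; beyond the scatter) and so turns the pyridine-bearing compound 3 into a far stronger inhibitor. For the compounds shown here, this is the first view of this position, and it shows that replacing a single hydrogen here with a ring of 5 heavy atoms can shift the number greatly and does not cost activity. Nothing measured here explains why the change has so large an effect.

Going by these compounds, whether this step depends on pyrrolidin-1-yl itself stays open. A morpholine ring, a dimethylamino group or a methoxy group at the same place would help to show how specific it is.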